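Furan replaces fluorophenyl in a thiosemicarbazone series

The source may report more compounds than this note shows. Statements on the series, on what has been measured and on what is new or still open speak of the compounds shown alone.

Compound 1, `CC1=CC[C@H](C(C)(C)NC(=S)N/N=C/c2ccccc2)CC1`: 20600 nM in a functional assay on OVCAR-3 cells (Homo sapiens) for inhibition, read by sulforhodamine B assay, with a stated time of 48 h; a lower number here means a stronger inhibitor of growth, a higher number a weaker inhibitor of growth
Compound 2, `CC1=CC[C@H](C(C)(C)NC(=S)N/N=C/c2ccc(F)cc2)CC1`: a limit of > 100000 nM in this assay

The number for compound 2 is only a limit of this assay, not a measured value, so compound 2 stands at the limit of > 100000 nM in this assay, at which 1 of the 2 values shown sits. Among the measured compounds shown here, the only step that is known, an at least 4.8-fold higher number from compound 1 to compound 2 (0.68 log units; beyond the scatter), is itself bounded by that same limit. Compound 3, `CC1=CC[C@H](C(C)(C)NC(=S)N/N=C/c2ccco2)CC1`, carries furan-2-yl in place of 4-fluorophenyl on a carbon with a double bond to nitrogen. For the measured compounds named here, no measured step here changes the aromatic ring itself, so the step from compound 2 to compound 3 cannot be read from the known data with any confidence. The reference point for what a compound of this core can reach is compound 1 at 20600 nM. For compound 3, the expected step is an at least 2.2-fold lower number from compound 2 to compound 3 (0.34 log units; beyond the scatter), in the direction of a lower number. The estimate for compound 3 in this assay is 45000 nM, within a range from 12000 nM to 150000 nM.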

Compound 3, concentration for total growth inhibition: 13800 nM
Beside the measured number, compound 3's estimate is 3.3-fold (0.51 log units) above it; measured number inside the range.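

In this assay, the ring on the carbon with a double bond to nitrogen could be exchanged without the loss seen with fluoro: furan-2-yl in place of 4-fluorophenyl gives an at least 7.2-fold lower number from compound 2 to compound 3 (0.86 log units; beyond the scatter). The size of that step is only a bound, and compound 2 stands at a limit of the assay: the limit of > 100000 nM in this assay, at which 1 of the 3 values shown sits.

Furan-2-yl in place of phenyl gives a 1.5-fold lower number from compound 1 to compound 3 (0.17 log units; within the scatter), so the two rings cannot be told apart in this assay, and the first change of the aromatic ring itself leaves the number where the phenyl ring had it. As far as these compounds go, whether the loss in compound 2 belongs to fluoro alone, or would also follow a chlorine or a methoxy group on the phenyl ring, stays open. So does whether a thiophene or a pyridine ring at this place would match compound 1 and compound 3.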